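This account rests on a few compounds, and the source may have more. Where it says the series, first, only, none or still open, it means among the compounds named here.

Measured so far in a functional assay on SK-BR-3 cells (Homo sapiens) for antiproliferative activity, read by MTT assay, with a stated time of 72 h; on this read-out higher numbers stand for weaker inhibition and lower numbers for stronger inhibition:
Compound 1 `CCN1CCN(c2cc(C)c3cc(NC(=O)c4ccc(C)cc4)ccc3n2)CC1` gives 11400 nM.
Compound 2 `CNc1cc(C)c2cc(NC(=O)c3ccc(Cl)c(Cl)c3)ccc2n1` gives 6350 nM.
Compound 3 `CCN1CCN(c2cc(C)c3cc(NC(=O)c4ccc(Br)cc4)ccc3n2)CC1` gives 6310 nM.

Compound 2 stands second highest of the three numbers; against compound 3 the difference is nil, against compound 1 it is within the scatter, so the three values are not separated. The next compound, compound 4 `Cc1cc(N2CCN(C(C)C)CC2)nc2ccc(NC(=O)c3ccc(Cl)c(Cl)c3)cc12`, differs from compound 2 by 4-isopropylpiperazin-1-yl in place of methylamino on an aromatic carbon.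

Within the data shown here, the only single-point step on record, a 1.8-fold lower number from compound 1 to compound 3 (0.26 log units; within the scatter), concerns the amide aryl group and not the position changed here, and it stays within the scatter. Among the measured compounds shown here, compounds 1 and 3 already carry a piperazinyl group at this position, and their values sit beside that of compound 2 within the scatter, though both differ from compound 2 in two places, so no clean step for this change exists. Nothing in the data points beyond the scatter. The expected step of a 1.0-fold higher number from compound 2 to compound 4 (0.01 log units; within the scatter) is therefore near nil. Compound 4 is estimated at 6500 nM in this assay, with a range of 2200 nM to 19000 nM.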

Compound 4, half-maximal inhibitory concentration: 6680 nM
Compound 4: middle estimate off by 1.0-fold (0.01 log units), on the low side, and the stated range covers the measured number.
By their numbers in this assay, from the lowest: compounds 3, 2, 4 and 1 (each within the scatter of the next).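

Among these compounds, with the rest of the molecule unchanged, replacing methylamino by 4-isopropylpiperazin-1-yl next to the ring nitrogen gives a 1.1-fold higher number from compound 2 to compound 4 (0.02 log units; within the scatter) in this assay, the first direct reading of a change at this position. The position therefore accepts the entering group, with 9 heavy atoms, a six-membered non-aromatic ring and 0 hydrogen-bond donors, in place of a group with 2 heavy atoms and 1 hydrogen-bond donor, and the step stays within the scatter. No supporting data are available to explain this result.

This single pair leaves open whether the position tolerates every group or only these two. A morpholin-4-yl group, an unsubstituted piperazin-1-yl group or a chain ending in a carboxylic acid would test whether any replacement here moves the number beyond the scatter.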